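A few compounds are considered here, and "the series" means these few. Any claim that something is new, unique, unknown or untested is made for them only; others in the source may bear on it.

Measured compounds in a functional assay on MDA-MB-231 cells (Homo sapiens) for cytotoxicity, read by MTT assay, with a stated time of 72 h; on this read-out lower numbers stand for stronger inhibition and higher numbers for weaker inhibition:
- compound 1, `COc1cc2c(Oc3ccc(NC(=O)c4nn(-c5cccc(F)c5)c(=O)c5ccccc45)cc3F)ccnc2cc1OCCCN1CCCC1`, gives 880 nM
- compound 2, `COc1cc2c(Oc3ccc(NC(=O)c4nn(-c5ccccc5F)c(=O)c5ccccc45)cc3F)ccnc2cc1OCCCN1CCCC1`, gives 950 nM
- compound 3, `COc1cc2c(Oc3ccc(NC(=O)c4nn(-c5cccc(F)c5)c(=O)c5ccccc45)cc3F)ccnc2cc1OCCCN1CCC(C)CC1`, gives 860 nM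

All three numbers sit within the scatter of one another in this assay, so no ordering among them is claimed. The change from compound 1 to compound 2 is 2-fluorophenyl in place of 3-fluorophenyl on an aromatic nitrogen, and it made a step of a 1.1-fold higher number from compound 1 to compound 2 (0.03 log units; within the scatter). The change from compound 1 to compound 3 is 4-methylpiperidin-1-yl in place of pyrrolidin-1-yl on a saturated chain carbon, three bonds along the chain from an oxygen on an aromatic ring, with a step of a 1.0-fold lower number from compound 1 to compound 3 (0.01 log units; within the scatter).

Compound 4, `COc1cc2c(Oc3ccc(NC(=O)c4nn(-c5ccccc5F)c(=O)c5ccccc45)cc3F)ccnc2cc1OCCCN1CCC(C)CC1`, has not been measured in this assay. It differs from compound 3 by 2-fluorophenyl in place of 3-fluorophenyl on an aromatic nitrogen. This is the same change as that from compound 1 to compound 2, at the same place, here made on the core of compound 3 rather than the core of compound 1; the two cores differ by 4-methylpiperidin-1-yl in place of pyrrolidin-1-yl on a saturated chain carbon, three bonds along the chain from an oxygen on an aromatic ring.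

The step from compound 3 to compound 4 in this assay is expected to be a 1.1-fold higher number from compound 3 to compound 4 (0.03 log units; within the scatter), resting on the near-flat step a 1.1-fold higher number from compound 1 to compound 2 (0.03 log units; within the scatter) seen for the same change. Compound 4 is therefore estimated at 930 nM, with a range from 500 nM to 1700 nM.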

Compound 4, half-maximal inhibitory concentration: 670 nM
The estimate for compound 4 lay 1.4-fold (0.14 log units) above the measured number; measured number inside the range.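

On the core carrying 4-methylpiperidin-1-yl, 2-fluorophenyl in place of 3-fluorophenyl gives a 1.3-fold lower number from compound 3 to compound 4 (0.11 log units; within the scatter), and this step agrees with the one on the core carrying pyrrolidin-1-yl: the same change on two cores in this assay, a 1.1-fold higher number (0.03 log units; within the scatter) from compound 1 to compound 2 and a 1.3-fold lower number (0.11 log units; within the scatter) from compound 3 to compound 4, 1.4-fold (0.14 log units) apart, within the scatter of two such steps. With 2-fluorophenyl in place, 4-methylpiperidin-1-yl in place of pyrrolidin-1-yl gives a 1.4-fold lower number from compound 2 to compound 4 (0.15 log units; within the scatter), and this step agrees with the one seen with 3-fluorophenyl: the same change on two cores in this assay, a 1.0-fold lower number (0.01 log units; within the scatter) from compound 1 to compound 3 and a 1.4-fold lower number (0.15 log units; within the scatter) from compound 2 to compound 4, 1.4-fold (0.14 log units) apart, within the scatter of two such steps. In this assay, for the compounds shown here, both changes therefore carry across these two cores without a detectable difference, but all four steps are small, so this shows only that near-flat steps stay near-flat within this one set of four compounds, not that a larger step would carry over or that other cores would behave alike.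

As far as these compounds go, it remains open whether another group on the aromatic nitrogen, such as 4-fluorophenyl, unsubstituted phenyl or 2-chlorophenyl, would give a step beyond the scatter. The same question stands for another amine at the end of the chain, such as morpholin-4-yl or dimethylamino, and for a longer chain.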